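Shortening a Hydroxyalkyl Chain on a Shared Core

The source may report more compounds than this note shows. Statements on the series, on what has been measured and on what is new or still open speak of the compounds shown alone.

Two compounds have been measured in an assay on isolated protein for binding affinity to adenosine receptor A1 (Bos taurus); on this read-out higher numbers stand for weaker inhibition and lower numbers for stronger inhibition:

Compound 1, `c1ccc(Cn2nnc3c(NC4CCCC4)nc(-c4ccccc4)nc32)cc1`: 11000000 nM
Compound 2, `OCCCNc1nc(-c2ccccc2)nc2c1nnn2Cc1ccccc1`: 21400000 nM

Compound 1 and compound 2 share one core and differ only in the group on the ring nitrogen, a cyclopentyl in compound 1 and a 3-hydroxypropyl in compound 2. The step of a 1.9-fold higher number from compound 1 to compound 2 (0.29 log units; within the scatter) shows that this swap left the number essentially unchanged, so compound 2 and compound 1 sit within the scatter of each other and neither can be called the weaker or stronger binder.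

Compound 3, `OCCNc1nc(-c2ccccc2)nc2c1nnn2Cc1ccccc1`, has not been measured. It differs from compound 2 by hydroxy in place of hydroxymethyl on a saturated chain carbon, two bonds along the chain from a nitrogen on an aromatic ring; put another way, the 3-hydroxypropyl chain becomes a 2-hydroxyethyl chain, one carbon shorter, with the same donor and acceptor count.

Within the data shown here, only the step from compound 1 to compound 2 bears on this change, and it was within the scatter even though it replaced a ring with a chain. A shortening by one chain carbon is a smaller alteration, so in this assay no step beyond the scatter is expected, in either direction. Compound 3 is therefore expected to give about 20000000 nM, with a range from 7000000 nM to 60000000 nM, an estimated step of a 1.1-fold lower number from compound 2 to compound 3 (0.03 log units; within the scatter).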

Compound 3, inhibition constant: 38000000 nM
The estimate for compound 3 lay 1.9-fold (0.28 log units) below the measured number; low and high end bracket the measured number.
By their numbers in this assay, from the lowest: compounds 1, 2 and 3 (each within the scatter of the next, the first and the last beyond it).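

In this assay, shortening 3-hydroxypropyl to 2-hydroxyethyl gives a 1.8-fold higher number from compound 2 to compound 3 (0.25 log units; within the scatter), so losing one chain carbon does not clearly separate these two hydroxyalkyl compounds. The new information comes from the comparison with the cyclopentyl compound: replacing cyclopentyl with 2-hydroxyethyl gives a 3.5-fold higher number from compound 1 to compound 3 (0.54 log units; beyond the scatter), a modest step and the only one among these compounds beyond the scatter, whereas replacing it with 3-hydroxypropyl gave a 1.9-fold higher number from compound 1 to compound 2 (0.29 log units; within the scatter). Compound 3 therefore binds more weakly than compound 1, while compound 2 cannot be separated from either of them, and the data shown offer no explanation for this pattern.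

On these data alone, it remains open whether a longer chain such as 4-hydroxybutyl would match these results, and whether the hydroxy itself matters, which a plain propyl chain or an amine in its place could help to show. As far as these compounds go, it is also open whether any other group on the same nitrogen could bring the number far below that of compound 1, 11000000 nM.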